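Replacing a side chain on the shared core

This account rests on a few compounds, and the source may have more. Where it says the series, first, only, none or still open, it means among the compounds named here.

Compound 1 `CCCCCCCCCCc1ccc(-c2noc(CCCNC)n2)cc1` and compound 2 `CCCCCCCCCCc1ccc(-c2noc([C@H](CCCCN)NC(C)=O)n2)cc1` share the same core and differ only in the group attached to one aromatic carbon. In an assay on HeLa cells for inhibition of sphingosine-1-phosphate transporter SPNS2 (Mus musculus), read by LC-MS, tested at 2 uM (a higher number here means more inhibition at the concentration tested (going by the name of the read-out), a lower number less inhibition), compound 1 gives 45%, and compound 2 gives 40%. Among the two measured numbers compound 2 has the lower one, yet the step of a number 5 percentage points lower from compound 1 to compound 2 (within the scatter) lies within the scatter, so the two compounds cannot be ranked against each other.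

Compound 3 `CCCCCCCCCCc1ccc(-c2noc(CC(O)CN(C)C)n2)cc1` has not yet been measured. The change from compound 2 to compound 3 is 3-(dimethylamino)-2-hydroxypropyl in place of 1-acetamido-5-aminopentyl on an aromatic carbon. For the measured compounds named here, the only measured step that bears on it is the one from compound 1 to compound 2, which also swapped the group on this aromatic carbon and amounted to a number 5 percentage points lower from compound 1 to compound 2 (within the scatter), a shift inside the scatter. Two such swaps so far have moved the read-out little, so a further swap of this kind is expected to do the same.

Compound 3 is therefore expected to give 40%, with a likely range from 25% to 55%. This expectation corresponds to a step of no change at the digits printed from compound 2 to compound 3 (within the scatter), estimated to stay within the scatter.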

Compound 3, a percentage reported as inhibition, at one concentration (the size of the read-out at that concentration, not a potency): 61%
For compound 3 the middle estimate is 21 percentage points below the measured one; the whole stated range lies below it.
By their numbers in this assay, from the lowest: compounds 2 and 1 (each within the scatter of the next); then compound 3.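

In this assay, the side chain on this aromatic carbon of the five-membered aromatic ring with 2 nitrogen and 1 oxygen now proves able to change the read-out: putting 3-(dimethylamino)-2-hydroxypropyl in place of 1-acetamido-5-aminopentyl gives a number 21 percentage points higher from compound 2 to compound 3 (beyond the scatter), whereas compound 1 and compound 2 could not be told apart. The second comparison agrees, since 2-(dimethylamino)-1-hydroxyethyl in place of 2-(methylamino)ethyl on a saturated chain carbon bound to an aromatic carbon gives a number 16 percentage points higher from compound 1 to compound 3 (beyond the scatter), which places compound 3 clear of both other compounds and shows that a change confined to this part of the side chain is enough to separate them. No measurement is available that explains this rise.

The change from compound 1 to compound 3 adds a hydroxy group and a second methyl on the nitrogen together, so a 3-(dimethylamino)propyl group on the same carbon would be needed to tell these two changes apart. From the compounds shown here alone, it also remains open whether the amine is needed at all, a question that a plain 2-hydroxypropyl group at this place would address.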